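Hydroxy to amino on the aryl ester arm

The source may hold more compounds than are shown below. What is called first, only, known or untested is meant among the compounds shown, and "the series" means these compounds.

Two esters on a shared core have been read so far in a functional assay on HCT-116 cells (Homo sapiens) for inhibition; a lower number here means a stronger inhibitor, a higher number a weaker inhibitor. Compound 1 `C=CC(=O)OCc1cc(=O)oc2cc(OC)c(OC)cc12` gives > 10 ug/mL, which is a limit of the assay and not a number. Within the data shown here, compound 2 `COc1cc2oc(=O)cc(COC(=O)/C=C/c3ccc(O)cc3)c2cc1OC` gives 5.21 ug/mL, the only true number.

Compound 3 `COc1cc2oc(=O)cc(COC(=O)/C=C/c3ccc(N)cc3)c2cc1OC` keeps everything in compound 2 except one group: amino in place of hydroxy on an aromatic carbon.

Among the measured compounds shown here, one measured step bears on this, the 2-(4-hydroxyphenyl)ethenyl in place of vinyl on a carbonyl carbon, which gives an at least 1.9-fold lower number from compound 1 to compound 2 (0.28 log units; that floor lies within the scatter). That step rests on (the limit of > 10 ug/mL in this assay, at which 1 of the 2 values shown sits), and it exchanges the whole arm, so it does not test the hydroxy alone. For the measured compounds named here, no measured pair changes that group by itself.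

The working expectation therefore stays close to compound 2 at 5.21 ug/mL, with no direction favoured. The expected change is a 1.0-fold lower number from compound 2 to compound 3 (0.02 log units; within the scatter), with no step beyond the scatter foreseen. For compound 3 the estimate is 5 ug/mL, with an expected range of 2.2 ug/mL to 10 ug/mL.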

Compound 3, half-maximal inhibitory concentration: > 10 ug/mL
Compound 3 was reported as a limit; the forecaster's own chance of this, stated with the estimate: 20%; at least 2.0-fold (0.30 log units) between middle value and limit.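

In this assay, among these compounds, amino in place of hydroxy on the aromatic carbon, para to a large group, is the first change of this group alone, and it gives an at least 1.9-fold higher number from compound 2 to compound 3 (0.28 log units; that floor lies within the scatter). Compound 3 gives > 10 ug/mL, which is a limit of the assay and not a number. The step therefore fixes no size and, with its floor inside the scatter, shows no firm loss on going from hydroxy to amino; the step between compound 1 and compound 3 cannot be read, and most of the series now rests on one limit: the limit of > 10 ug/mL in this assay, at which 2 of the 3 values shown sit.

As far as these compounds go, compound 2 remains the only ester with a true number, so a single value carries all that is known about this position, and it is open whether the hydroxy itself matters or whether the 2-(4-hydroxyphenyl)ethenyl arm as a whole does. A methoxy group or a chlorine on the same aromatic carbon, or an unsubstituted phenyl in the arm, would test this, and only a value that is a number rather than a limit could give the size of such a step.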